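Methylsulfonyl for methylsulfanyl across two cores

The source may report more compounds than this note shows. Statements on the series, on what has been measured and on what is new or still open speak of the compounds shown alone.

Measured so far:
compound 1 `CS(=O)(=O)c1ccc(F)cc1NCC1=NCCN1`: 91%
compound 2 `CSc1ccc(F)cc1NCC1=NCCN1`: 97%
compound 3 `CSc1c(F)cccc1NCC1=NCCN1`: 104%

All three numbers come from a functional assay on CHO cells for agonist activity at Alpha-2C adrenergic receptor (Homo sapiens); on this read-out higher numbers stand for larger maximal responses and lower numbers for smaller maximal responses. Compound 3 stands highest, yet its gap to compound 2 lies within the scatter, so no order between them is claimed.

From compound 2 to compound 1 the change is methylsulfonyl in place of methylsulfanyl on an aromatic carbon, and the step was a number 6 percentage points lower from compound 2 to compound 1 (within the scatter). The difference between the cores of compound 2 and compound 3 is not broken down here.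

Compound 4 `CS(=O)(=O)c1c(F)cccc1NCC1=NCCN1` is not yet measured. From compound 3 it differs by methylsulfonyl in place of methylsulfanyl on an aromatic carbon, the same kind of change as before, but here the place is ortho to a fluoro group rather than para to it.

Because the earlier step of a number 6 percentage points lower from compound 2 to compound 1 (within the scatter) stayed within the scatter, a step of a number 6 percentage points lower from compound 3 to compound 4 (within the scatter) is expected from compound 3 to compound 4. Compound 4 is thus estimated at 98% in this assay.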

Compound 4, largest response reached (reported as maximum), in percent of the reference or control that the assay uses: 93%
For compound 4 the middle estimate is 5 percentage points above the measured one; low and high end bracket the measured number.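

In this assay, methylsulfonyl in place of methylsulfanyl on an aromatic carbon gives a number 11 percentage points lower from compound 3 to compound 4 (beyond the scatter), and this step does not stand apart from the earlier one: the same change on two cores in this assay, a number 6 percentage points lower (within the scatter) from compound 2 to compound 1 and a number 11 percentage points lower (beyond the scatter) from compound 3 to compound 4, 5 percentage points apart, within the scatter of two such steps. For the compounds shown here, the change thus carries between these two cores as far as this assay can resolve, although only the step on the core of compound 3 lies beyond the scatter. Two pairs in a single assay do not show that it would carry to a further core, nor what in the cores might set the steps apart.

At this place the compounds shown hold only methylsulfanyl and methylsulfonyl, so an amine, a carboxylic acid or a longer chain such as ethylsulfonyl remains open. From the compounds shown here alone, whether the step holds with chloro instead of the fluoro group also remains open.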